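Compound 1 to compound 3: no readable step yet

The source may report more compounds than this note shows. Statements on the series, on what has been measured and on what is new or still open speak of the compounds shown alone.

In an ADME assay on Raji cells (Homo sapiens) for cytotoxicity, with a stated time of 72 h (on this read-out lower numbers stand for an effect already at smaller amounts and higher numbers for an effect only at larger amounts of compound), compound 1 (`Cc1cc(NC(=O)Nc2ccc(F)cc2)c2ccccc2n1`) gives > 25000 nM as a limit and not as a number. Compound 2 (`Cc1cc(NC(=O)Nc2ccc(C(N)=O)cc2)c2ccccc2n1`) gives > 25000 nM and this too is a limit. Among the compounds with values here, neither compound yields a number (the series so far: the limit of > 25000 nM in this assay, at which 2 of the 2 values shown sit).

Compound 3 (`Cc1cc(NC(=O)Nc2cccnc2)c2ccccc2n1`) keeps the core of compound 1 and carries pyridin-3-yl in place of 4-fluorophenyl on an amide-type nitrogen.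

Within the data shown here, only one measured step bears on this change, and it concerns a different replacement, carbamoyl in place of fluoro on an aromatic carbon. That step, a step that the two limits leave unreadable from compound 1 to compound 2, gives neither a size nor a direction. It does show that compound 2 stays at the same limit as compound 1, so no step beyond the scatter is expected in this assay for compound 3. The expected step, a number no higher from compound 1 to compound 3 (the limit leaves the size open), is therefore an estimate with no direction behind it. For compound 3 an estimate of 25000 nM is expected (estimated range 10000 nM to 50000 nM), most likely reported again as a limit.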

Compound 3, half-maximal effective concentration: > 25000 nM
Compound 3 was reported as a limit (the forecaster's own chance of this, stated with the estimate: 85%); the middle value lies on the limit itself.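

In this assay compound 3 gives > 25000 nM, which is a limit and not a number. No step can be read from compound 1 to compound 3, so pyridin-3-yl in place of 4-fluorophenyl has neither size nor direction here: the limit of > 25000 nM in this assay, at which 3 of the 3 values shown sit.

The compounds shown leave open what concentration, if any, gives a half-maximal effect in this assay.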